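A few compounds are considered here, and "the series" means these few. Any claim that something is new, unique, unknown or untested is made for them only; others in the source may bear on it.

Compound 1, whose structure is `O=C(/C=C\Nc1ccc(C(F)(F)F)cc1)c1cn(-c2ccccc2)nc1-c1ccc(F)cc1`, is the starting point of this series. In a functional assay on U-87MG ATCC cells (Homo sapiens) for antiproliferative activity, read by MTT assay, with a stated time of 48 h (on this read-out lower numbers stand for stronger inhibition and higher numbers for weaker inhibition), compound 1 returns only a limit, > 50000 nM, not a number. Compound 2, `O=C(/C=C\Nc1ccc(O)cc1)c1cn(-c2ccccc2)nc1-c1ccc(F)cc1`, differs from it by a single change, (hydroxy in place of trifluoromethyl on an aromatic carbon), and in this assay compound 2 gives 4700 nM. That change brings an at least 10-fold lower number from compound 1 to compound 2 (1.02 log units; beyond the scatter), a step that is read against the limit at which the first compound sits, (the limit of > 50000 nM in this assay, at which 2 of the 3 values shown sit).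

Compound 3, `COc1cc(-c2nn(-c3ccccc3)cc2C(=O)/C=C\Nc2ccc(C(F)(F)F)cc2)cc(OC)c1OC`, carries a different core: 3,4,5-trimethoxyphenyl in place of 4-fluorophenyl on an aromatic carbon. In this assay compound 3 also stops at a limit, > 50000 nM, so the two values give a step that the two limits leave unreadable from compound 1 to compound 3.

Compound 4, `COc1cc(-c2nn(-c3ccccc3)cc2C(=O)/C=C\Nc2ccc(O)cc2)cc(OC)c1OC`, has not yet been measured in this assay. It stands to compound 3 as compound 2 stands to compound 1: hydroxy in place of trifluoromethyl on an aromatic carbon, and the place lines read the same word for word, so this is the same change. If the same change repeats its effect on the core of compound 3, compound 4 is expected to show an at least 5.5-fold lower number from compound 3 to compound 4 (0.74 log units; beyond the scatter), resting on the step seen from compound 1 to compound 2, an at least 10-fold lower number from compound 1 to compound 2 (1.02 log units; beyond the scatter). On that basis compound 4 is estimated at 9000 nM in this assay, with a range from 2500 nM to 50000 nM expected.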

Compound 4, half-maximal inhibitory concentration: 1800 nM
Compound 4: middle estimate off by 5.0-fold (0.70 log units), on the high side, outside the stated range (below it).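

In this assay the replacement of trifluoromethyl by hydroxy again lowers the number, giving an at least 27-fold lower number from compound 3 to compound 4 (1.44 log units; beyond the scatter), so the direction seen on the core of compound 1 also appears on the core of compound 3. Both steps start from a limit rather than a number, so their sizes cannot be set against each other: the same change on two cores in this assay, an at least 10-fold lower number (1.02 log units; beyond the scatter) from compound 1 to compound 2 and an at least 27-fold lower number (1.44 log units; beyond the scatter) from compound 3 to compound 4; the limit leaves it open whether they differ. The result shows the same direction on these two cores only; it does not show that the change has the same size on both, that it is larger on one, or that it would carry to any further core.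

The compounds shown leave open whether an amine or a carboxylic acid in the place of the hydroxy would also give a lower number than trifluoromethyl on either core. Also open, as far as these compounds go, is where compound 1 and compound 3 would read as actual numbers, and with that the true size of each step.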